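Trimming the distal ring of a bile acid receptor ligand

The source may hold more compounds than are shown below. What is called first, only, known or untested is meant among the compounds shown, and "the series" means these compounds.

Compound 1 `COC(=O)/C=C/c1cccc(N(Cc2ccc(-c3ccc(OC)cc3)cc2)C(=O)C2CCCCC2)c1` carries a cyclohexyl group on its carbonyl carbon. In an assay on isolated protein with Bile acid receptor (Homo sapiens) as the target (on this read-out higher numbers stand for an effect only at larger amounts of compound and lower numbers for an effect already at smaller amounts), compound 1 gives 89 nM, the lowest of the two numbers recorded, although its nearest neighbour sits within the scatter. That neighbour, compound 2 `COC(=O)/C=C/c1cccc(N(Cc2ccc(-c3ccc(OC)cc3)cc2)C(=O)C(C)C)c1`, has isopropyl in place of cyclohexyl, and in this assay compound 2 gives 97 nM. The step of a 1.1-fold higher number from compound 1 to compound 2 (0.04 log units; within the scatter) stays within the scatter, so the group on the carbonyl carbon appears interchangeable here. Compound 3 `COC(=O)/C=C/c1cccc(N(Cc2ccccc2)C(=O)C2CCCCC2)c1` differs from compound 1 elsewhere: hydrogen in place of 4-methoxyphenyl on an aromatic carbon. For the measured compounds named here, no measured step touches the 4-methoxyphenyl group, and the single step on record concerns the carbonyl substituent only, so it offers no guidance. Removing an entire aromatic ring exceeds any change measured so far, and compound 3 is therefore expected to give 1200 nM, estimated between 300 nM and 6000 nM, which would mean a step of a 13-fold higher number from compound 1 to compound 3 (1.13 log units; beyond the scatter).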

Compound 3, half-maximal effective concentration: > 1000 nM
Compound 3 was reported as a limit; the forecaster's own chance of this, stated with the estimate: 15%; the middle value does not contradict the limit.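

Compound 3 gives > 1000 nM in this assay, and this value is a limit of the assay, not a number. The earlier compounds had shown only that the group on the carbonyl carbon could change within the scatter, whereas hydrogen in place of 4-methoxyphenyl on this aromatic carbon, para to a large group, is a large step: an at least 11-fold higher number from compound 1 to compound 3 (1.05 log units; beyond the scatter). Its true size stays unknown, as the step rests on a limit: the limit of > 1000 nM in this assay, at which 1 of the 3 values shown sits.

The compounds shown leave open whether a smaller group on this carbon, such as methoxy or a chlorine atom, would keep the number close to that of compound 1. They also leave open whether a phenyl ring without its methoxy group, or one carrying a carboxylic acid, would do the same.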